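Phenylsulfonyl for 3-Chlorobenzyl on a Second Core

This account rests on a few compounds, and the source may have more. Where it says the series, first, only, none or still open, it means among the compounds named here.

Compound 1 `C#CCNC1CCc2c(OCCCCN3CCN(c4cccc5c4ccn5Cc4cccc(Cl)c4)CC3)cccc21` and compound 2 `C#CCNC1CCc2c(OCCCCN3CCN(c4cccc5c4ccn5S(=O)(=O)c4ccccc4)CC3)cccc21` share one core and differ in a single place, described as phenylsulfonyl in place of 3-chlorobenzyl on an aromatic nitrogen. In an assay on HEK293 cells for displacement of a labelled ligand from 5-hydroxytryptamine receptor 6 (Homo sapiens), read by scintillation counting, with a stated time of 1 h (a lower number here means a stronger inhibitor, a higher number a weaker inhibitor), compound 1 gives 113 nM, while compound 2 gives 50 nM, so the change produced the step of a 2.3-fold lower number from compound 1 to compound 2 (0.35 log units; beyond the scatter).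

Compound 3 `C[C@H](NCc1ccc(OCCCCN2CCN(c3cccc4c3ccn4Cc3cccc(Cl)c3)CC2)cc1)C(N)=O` is built on another core; how the two cores differ is not broken down here. In this assay compound 3 gives 162 nM, a number that lies within the usual scatter of compound 1 but beyond it relative to compound 2.

Compound 4 `C[C@H](NCc1ccc(OCCCCN2CCN(c3cccc4c3ccn4S(=O)(=O)c3ccccc3)CC2)cc1)C(N)=O` applies the same change to the core of compound 3, described as phenylsulfonyl in place of 3-chlorobenzyl on an aromatic nitrogen, at a place that matches the earlier one word for word. Since the two examples share the same change at the same kind of place, compound 4 is expected to show the step of a 2.3-fold lower number from compound 3 to compound 4 (0.36 log units; beyond the scatter), resting on the step of a 2.3-fold lower number from compound 1 to compound 2 (0.35 log units; beyond the scatter) seen on the first core. Compound 4 is therefore estimated at 70 nM in this assay, expected to fall between 30 nM and 160 nM.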

Compound 4, inhibition constant: 68 nM
Beside the measured number, compound 4's estimate is 1.0-fold (0.01 log units) above it, and the stated range covers the measured number.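

On the core of compound 3, phenylsulfonyl in place of 3-chlorobenzyl on an aromatic nitrogen gave a 2.4-fold lower number from compound 3 to compound 4 (0.38 log units; beyond the scatter) in this assay. Set beside the earlier step, the change carried over from one core to the other with no difference in size that rises above the scatter: the same change on two cores in this assay, a 2.3-fold lower number (0.35 log units; beyond the scatter) from compound 1 to compound 2 and a 2.4-fold lower number (0.38 log units; beyond the scatter) from compound 3 to compound 4, 1.1-fold (0.02 log units) apart, within the scatter of two such steps

This agreement rests on one change, two cores and one assay, so it shows that the step held its size on these two pairs but does not show that it would hold on a further core, and it gives no reason for the lower number.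

The compounds shown leave open which part of the change matters, as the entering group lacks the chlorine and also replaces the benzyl carbon with a sulfonyl, so a plain benzyl or a 3-chlorophenylsulfonyl on the same nitrogen would be needed to separate the two. They also leave open whether the step would persist with a longer chain elsewhere in the molecule.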